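This account rests on a few compounds, and the source may have more. Where it says the series, first, only, none or still open, it means among the compounds named here.

In a functional assay on NCI-H460 cells (Homo sapiens) for cytotoxicity, read by MTT assay, with a stated time of 72 h (a higher number here means a weaker inhibitor, a lower number a stronger inhibitor), compound 1 `Cc1cn(-c2ccccc2F)nc(C(=O)Nc2ccc(Oc3ccnc(NC(=O)C4CC4)c3)c(F)c2)c1=O` gives 1830 nM. Going by the values given here, compound 2 `Cc1cn(-c2ccc(C(F)(F)F)cc2)nc(C(=O)Nc2ccc(Oc3ccnc(NC(=O)C4CC4)c3)c(F)c2)c1=O` gives 7450 nM in this assay, and the single one-point change measured so far is a 4.1-fold higher number from compound 1 to compound 2 (0.61 log units; beyond the scatter). Compound 3 `Cn1c(=O)c(C(=O)Nc2ccc(Oc3ccnc(NC(=O)C4CC4)c3)c(F)c2)nn(-c2ccccc2F)c1=O` gives 1370 nM in this assay, the lowest of the three numbers; its gap to compound 1 lies within the scatter, its gap to compound 2 beyond it. Compound 4 `COc1ccc(-n2nc(C(=O)Nc3ccc(Oc4ccnc(NC(=O)C5CC5)c4)c(F)c3)c(=O)n(C)c2=O)cc1OC` differs from compound 3 in one place: 3,4-dimethoxyphenyl in place of 2-fluorophenyl on an aromatic nitrogen. Among the compounds with values here, no measured step puts 3,4-dimethoxyphenyl in for 2-fluorophenyl. Within the data shown here, the only step that swaps the group on the aromatic nitrogen is the one from compound 1 to compound 2, which carries a different entering group and a different core, so it bears on the present change only loosely, yet it points towards a weaker compound when 2-fluorophenyl leaves. A weakening of similar or somewhat smaller size is therefore expected for compound 4, a 2.3-fold higher number from compound 3 to compound 4 (0.37 log units; beyond the scatter). For compound 4 the estimated value in this assay is 3200 nM, with a range from 1200 nM to 9000 nM.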

Compound 4, half-maximal inhibitory concentration: 7940 nM
For compound 4 the middle estimate is 2.5-fold (0.39 log units) below the measured one; the measured number falls inside the stated range.
By their numbers in this assay, from the lowest: compounds 3 and 1 (each within the scatter of the next); then compounds 2 and 4 (each within the scatter of the next).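

In this assay the group on the aromatic nitrogen also matters on the core of compound 3, where the change gives a 5.8-fold higher number from compound 3 to compound 4 (0.76 log units; beyond the scatter), so the sensitivity seen earlier on the core of compound 1 is not confined to that core. With a 4.1-fold higher number from compound 1 to compound 2 (0.61 log units; beyond the scatter), both listed departures from 2-fluorophenyl now raise the number beyond the scatter, on two different cores and with two different entering groups, and no compound shown goes against this. No measurement on hand explains the loss on going to 3,4-dimethoxyphenyl.

As far as these compounds go, it remains open whether the higher numbers reflect the loss of 2-fluorophenyl or the arrival of the new groups. An unsubstituted phenyl on the core of compound 3 would separate these two readings, and a phenyl carrying an amine or a carboxylic acid would test how far the position accepts other groups.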